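Piperazine nitrogen substituents on the shared core

This account rests on a few compounds, and the source may have more. Where it says the series, first, only, none or still open, it means among the compounds named here.

Measured so far:
compound 1, `CC(=O)N1CCN(c2nc(Nc3ccc(C#N)c(C(F)(F)F)c3)nc(Oc3ccnc4ccccc34)n2)CC1`, gives 75100 nM in a functional assay on DU-145 cells (Homo sapiens) for cytotoxicity, read by sulforhodamine B assay, with a stated time of 48 h; a higher number here means a weaker inhibitor of growth, a lower number a stronger inhibitor of growth.
compound 2, `N#Cc1ccc(Nc2nc(Oc3ccnc4ccccc34)nc(N3CCN(Cc4ccccc4)CC3)n2)cc1C(F)(F)F`, gives > 100000 nM in this assay, which is a limit of the assay and not a number.

Compound 2 thus sits at the limit of > 100000 nM in this assay, at which 1 of the 2 values shown sits; only a limit is known for it. Compound 3, `N#Cc1ccc(Nc2nc(Oc3ccnc4ccccc34)nc(N3CCN(c4ccccc4)CC3)n2)cc1C(F)(F)F`, differs by phenyl in place of benzyl on an amine nitrogen in a ring. For the measured compounds named here, no measured step matches this change; the only step known, an at least 1.3-fold higher number from compound 1 to compound 2 (0.12 log units; that floor lies within the scatter), is within the scatter. For compound 3 a step of a number no higher from compound 2 to compound 3 (the limit leaves the size open) is expected, so no shift beyond the scatter. The estimate for compound 3 is 100000 nM, range 50000 nM to 200000 nM.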

Compound 3, concentration for 50% growth inhibition: > 100000 nM
Compound 3: only a limit was reported; the forecaster's own chance of this, stated with the estimate: 50%; the middle value sits exactly at the limit.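

Benzyl in compound 2 and phenyl in compound 3 both end at the assay limit, which is a limit and not a number: the limit of > 100000 nM in this assay, at which 2 of the 3 values shown sit. The step between these two compounds cannot be read, so the one carbon that separates the two groups has no measurable consequence here. Phenyl in place of acetyl gives an at least 1.3-fold higher number from compound 1 to compound 3 (0.12 log units; that floor lies within the scatter).

The compounds shown leave open whether an amine on a longer chain or a carboxylic acid at this ring nitrogen would give a value clear of the limit in this assay. Going by these compounds, how far compound 2 and compound 3 lie beyond the limit also stays open.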